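From Aryl to Cyclohexyl on the Shared Core

The source may report more compounds than this note shows. Statements on the series, on what has been measured and on what is new or still open speak of the compounds shown alone.

Compound 3 `FC(F)(F)c1ccc(-c2ccc3c(NCCCNCc4ccco4)ccnc3c2)cc1` gives 3470 nM in an ADME assay on HepG2 cells (Homo sapiens) for cytotoxicity, read by luminescence, CellTiter-Glo and ATP content, with a stated time of 72 h (a lower number here means that less compound is needed, a higher number that more compound is needed for the effect), the lowest of the three measured numbers. Compound 1 `CC(C)CCc1ccc2c(NCCCNCc3ccco3)ccnc2c1` gives 11200 nM, and compound 2 `Fc1ccc(Oc2ccc3c(NCCCNCc4ccco4)ccnc3c2)cc1` gives 16000 nM. The measured steps were a 3.2-fold lower number from compound 1 to compound 3 (0.51 log units; beyond the scatter) and a 4.6-fold lower number from compound 2 to compound 3 (0.66 log units; beyond the scatter), whereas the change from isopentyl to 4-fluorophenoxy gave a 1.4-fold higher number from compound 1 to compound 2 (0.15 log units; within the scatter). Compound 4 `c1coc(CNCCCNc2ccnc3cc(C4CCCCC4)ccc23)c1` differs from compound 3 by cyclohexyl in place of 4-(trifluoromethyl)phenyl on an aromatic carbon. For the measured compounds named here, the step that bears on this most is the one from compound 1 to compound 3, where a group with a non-aromatic carbon chain was exchanged for an aromatic one; cyclohexyl is again non-aromatic, so that step is expected to be partly reversed, as a 2.3-fold higher number from compound 3 to compound 4 (0.36 log units; beyond the scatter). Compound 4 is estimated at 8000 nM, with a range from 3500 nM to 18000 nM.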

Compound 4, half-maximal effective concentration: 4760 nM
For compound 4 the middle estimate is 1.7-fold (0.23 log units) above the measured one, and the stated range covers the measured number.
By their numbers in this assay, from the lowest: compounds 3 and 4 (each within the scatter of the next); then compounds 1 and 2 (each within the scatter of the next).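

In this assay, exchanging an aromatic ring for a non-aromatic one at this position, with the trifluoromethyl group gone as well, gave a 1.4-fold higher number from compound 3 to compound 4 (0.14 log units; within the scatter). Cyclohexyl also stands apart from the other two groups, with a 3.4-fold lower number from compound 2 to compound 4 (0.53 log units; beyond the scatter) and a 2.4-fold lower number from compound 1 to compound 4 (0.37 log units; beyond the scatter), so among these four compounds a directly attached six-membered carbon ring gives the lower numbers, whether aromatic or not. No measurement shown accounts for this result.

As far as these compounds go, it remains open whether a cyclopentyl or piperidine ring at this place would stay with compound 3 and compound 4 or move toward compound 1 and compound 2. From the compounds shown here alone, whether plain phenyl would match 4-(trifluoromethyl)phenyl also remains open.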